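This account rests on a few compounds, and the source may have more. Where it says the series, first, only, none or still open, it means among the compounds named here.

Measured so far in a functional assay (Homo sapiens); on this read-out higher numbers stand for weaker inhibition and lower numbers for stronger inhibition:

Compound 1, `Nc1nc2ccnc(-c3cc[n+]([O-])cc3)n2n1`: compound 1 gives 5600 nM.
Compound 2, `CCOC(=O)c1ccc(-c2nccc3nc(N)nn23)cc1`: compound 2 gives 16500 nM.

Compound 2 stands at the highest of the two numbers in this assay; the gap down to compound 1 lies beyond the usual scatter, so compound 2 is the weaker of the two measured inhibitors. Among the measured compounds shown here, no step between two measured compounds that differ in one place is available, so the effect of any single change on the shared core rests on expectation alone.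

Compound 3, `Nc1nc2ccnc(-c3ccc(F)cc3)n2n1`, is the next compound to be measured in this assay. It differs from compound 2 as follows: fluoro in place of ethoxycarbonyl on an aromatic carbon. The ethoxycarbonyl that sits para to a large group in compound 2 is gone and only a fluoro remains at that aromatic carbon.

Given that the shared core with the pyridine N-oxide in compound 1 gives 5600 nM, a compound carrying a small fluoro is expected to land between the two measured numbers rather than beyond them. The step of a 2.1-fold lower number from compound 2 to compound 3 (0.31 log units; beyond the scatter) is expected to be a modest lowering, one that may not exceed the scatter. Compound 3 is estimated at 8000 nM, in a range from 2500 nM to 25000 nM.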

Compound 3, half-maximal inhibitory concentration: 31300 nM
Compound 3: middle estimate off by 3.9-fold (0.59 log units), on the low side; measured number above the stated range.
By their numbers in this assay, from the lowest: compound 1; then compounds 2 and 3 (each within the scatter of the next).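

In this assay, among the compounds shown here, fluoro in place of ethoxycarbonyl on an aromatic carbon, para to a large group, gives a 1.9-fold higher number from compound 2 to compound 3 (0.28 log units; within the scatter) and is the first single-place step available. At this position, the number therefore stays within the scatter although the substituent goes from five heavy atoms, with two hydrogen-bond acceptors and a double bond outside aromatic rings, to one heavy atom with no hydrogen-bond acceptors. Nothing at hand accounts for this result.

Going by these compounds, whether an amine or a carboxylic acid on the same aromatic carbon would shift the number beyond the scatter remains open. On these data alone, this reading rests on a single pair, so it covers only ethoxycarbonyl and fluoro at this position, and a longer chain there is still untested ground.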